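Adding an acetyl group to compound 3

The compounds below may be only part of what the source reports. "The series", "measured", "known", "first", "only" and "open" are said of these compounds alone.

Measured in a functional assay on MCF7 cells (Homo sapiens) for inhibition, read by CCK-8 assay, with a stated time of 48 h; a higher number here means a weaker inhibitor, a lower number a stronger inhibitor:
Compound 1 `COc1cc(-c2ccnc3cc(-c4ccc(C)cc4)nn23)cc(OC)c1OC`: 47 nM
Compound 2 `Cn1ccc2cc(-c3cc4nccc(-c5ccc(F)cc5)n4n3)ccc21`: 4580 nM
Compound 3 `COc1cc(-c2ccnc3cc(-c4ccccc4)nn23)cc(OC)c1OC`: 254 nM

Compound 3 holds the middle of the three numbers, higher than compound 1 and lower than compound 2. Compound 4 `COc1cc(-c2ccnc3cc(-c4ccc(C(C)=O)cc4)nn23)cc(OC)c1OC` alters compound 3 in one place: acetyl in place of hydrogen on an aromatic carbon. Compound 2 differs from compound 3 in more than one place, so it offers no clean comparison. Among the compounds with values here, the only measured step that bears on this change is a 5.4-fold higher number from compound 1 to compound 3 (0.73 log units; beyond the scatter), on the same aromatic carbon. An acetyl is not a methyl, so this is a loose guide, but a modest fall in the number is expected in this assay. The expected change is a 1.7-fold lower number from compound 3 to compound 4 (0.23 log units; within the scatter). Compound 4 is estimated at 150 nM, with an expected range of 40 nM to 600 nM.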

Compound 4, half-maximal inhibitory concentration: 5230 nM
Compound 4: the middle estimate sits 35-fold (1.54 log units) below what was measured, and the stated range ends below it.
By their numbers in this assay, from the lowest: compound 1; then compound 3; then compounds 2 and 4 (each within the scatter of the next).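

In this assay, the group on this aromatic carbon can move the number in either direction: methyl lowers it, while acetyl raises it sharply (a 21-fold higher number from compound 3 to compound 4 (1.31 log units; beyond the scatter)). The gap between the two groups at this one carbon is larger still (a 110-fold higher number from compound 1 to compound 4 (2.05 log units; beyond the scatter)), so a small change here can matter greatly. Nothing available explains why these two groups differ so much. Still open, as far as these compounds go, is where an ethyl group, a methoxy group or an amine on this carbon would fall. It is also unclear whether a carboxylic acid would behave like acetyl.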